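Removing a methyl from a saturated ring: cyclopentyl ether

The source may hold more compounds than are shown below. What is called first, only, known or untested is meant among the compounds shown, and "the series" means these compounds.

Measured so far:
compound 1 `CC1CCC(Oc2cccc3ccc(N)nc23)C1` — 823 nM
compound 2 `Nc1ccc2cccc(OC3CCCCCC3)c2n1` — 137 nM
compound 3 `CNc1ccc2cccc(OC(C)CC(C)(C)C)c2n1` — 310 nM

Of the compounds shown here, three have been tested in an assay on cells with melanin-concentrating hormone receptor 1 (Homo sapiens) as the target, read by radioligand binding; on this read-out higher numbers stand for weaker inhibition and lower numbers for stronger inhibition. Compound 1 stands highest of the three; compound 3 lies nearest with a lower number, and compound 2 furthest, its number lower still, both gaps beyond the scatter. Compound 4 `Nc1ccc2cccc(OC3CCCC3)c2n1` has not yet been measured. It differs from compound 1 in one place: hydrogen in place of methyl on a saturated ring carbon. No step between two measured compounds matches this change, so the direction of the effect cannot be read from the shown numbers. The larger saturated ring of compound 2 gives a lower number than compound 1, but the present change reduces the group rather than enlarging it. A step within the scatter, or a modest move toward a higher number, is expected for a 1.2-fold higher number from compound 1 to compound 4 (0.08 log units; within the scatter). Compound 4 is estimated at 1000 nM, with a range from 350 nM to 2800 nM.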

Compound 4, half-maximal inhibitory concentration: > 2000 nM
Compound 4 was reported as a limit; the forecaster's own chance of this, stated with the estimate: 5%; at least 2.0-fold (0.30 log units) between middle value and limit.
By their numbers in this assay, from the lowest: compound 2; then compound 3; then compound 1. At a limit, above all of these: compound 4.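

In this assay compound 4 stands at > 2000 nM and this is a limit of the assay, not a number. Taking away the methyl on a saturated ring carbon, two ring bonds from the ring atom that bears a large group, gives an at least 2.4-fold higher number from compound 1 to compound 4 (0.38 log units; beyond the scatter) and so shows that this position responds to the change from 3-methylcyclopentyl to cyclopentyl. How far the number moves stays unfixed: the limit of > 2000 nM in this assay, at which 1 of the 4 values shown sits.

The compounds shown leave open whether another group on this ring carbon, such as ethyl, a hydroxyl or an amine, would bring the number down further than methyl does.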